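Replacing chloro with phenoxy in a cytotoxicity series

The source may report more compounds than this note shows. Statements on the series, on what has been measured and on what is new or still open speak of the compounds shown alone.

For the measured compounds named here, in a functional assay on HGC-27 cells (Homo sapiens) for cytotoxicity, read by MTT assay, with a stated time of 48 h (a higher number here means a weaker inhibitor, a lower number a stronger inhibitor), compound 1 `COc1cc(OC)c(OC)cc1/C=C/C(=O)/C=C/c1cc2ccccc2nc1Cl` gives 8730 nM, the only actual number available so far. Compound 2 `COc1cc(OC)c(/C=C/C(=O)/C=C/c2cc3ccccc3nc2Cl)c(OC)c1` gives > 10000 nM in this assay, and this is a limit of the measurement, not a number. That leaves compound 1 as the sole firm reference point, with weak activity on this scale.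

Compound 3 `COc1cc(OC)c(OC)cc1/C=C/C(=O)/C=C/c1cc2ccccc2nc1Oc1ccccc1` keeps the core of compound 1 and differs from it in one place: phenoxy in place of chloro on an aromatic carbon. Phenoxy stands in place of chloro on an aromatic carbon, next to the ring nitrogen.

Going by the values given here, no measured pair shows this change, so no step beyond the usual scatter is expected in this assay, with only a slight lean towards stronger inhibition. The expected change is a 1.5-fold lower number from compound 1 to compound 3 (0.16 log units; within the scatter). For compound 3 the estimated value is 6000 nM, within an expected range from 1500 nM to 15000 nM.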

Compound 3, half-maximal inhibitory concentration: 10500 nM
Beside the measured number, compound 3's estimate is 1.8-fold (0.24 log units) below it, within the range that was stated.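

Phenoxy in place of chloro on an aromatic carbon, next to the ring nitrogen, is the only change in this assay that can be read as a step, and it gives a 1.2-fold higher number from compound 1 to compound 3 (0.08 log units; within the scatter). This pair shows that a group of 7 heavy atoms carrying a six-membered aromatic ring can stand where a single chlorine stood without the number moving beyond the scatter. Compound 2 stands at a limit and not at a number, so it offers no second step: the limit of > 10000 nM in this assay, at which 1 of the 3 values shown sits.

The compounds shown leave open whether an amine, a methoxy group or a longer chain at this position would move the number beyond the scatter. They also leave open whether phenoxy would act the same way on the core of compound 2, and one pair sets no pattern for this position.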